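The source may hold more compounds than are shown below. What is called first, only, known or untested is meant among the compounds shown, and "the series" means these compounds.

In an assay on isolated protein for binding affinity to melatonin receptor type 1B (Homo sapiens) (a higher number here means a weaker inhibitor, a lower number a stronger inhibitor), three compounds have been measured. Compound 1 `CCC(=O)Nc1ccc(Oc2cccc(OC)c2)cc1` gives 6.8 nM, and compound 2 `COCC(=O)Nc1ccc(Oc2cccc(OC)c2)cc1` gives 5.9 nM. Within the data shown here, the single step between these two, a 1.2-fold lower number from compound 1 to compound 2 (0.06 log units; within the scatter), shows that altering the chain attached to the carbonyl carbon left the number essentially unchanged. Compound 3 `COc1cccc(N(C)c2ccc(NC(C)=O)cc2)c1` gives 0.23 nM and stands at the lowest number of the three; its gaps to compound 1 and to compound 2 both lie beyond the scatter, so compound 3 is the strongest binder measured so far.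

Compound 4 `COc1cccc(N(C)c2ccc(NC(=O)C(C)C)cc2)c1` differs from compound 3 in one place: isopropyl in place of methyl on a carbonyl carbon. Among the measured compounds shown here, no measured step makes exactly this change. For the measured compounds named here, the only step that touches the chain on the carbonyl carbon, a 1.2-fold lower number from compound 1 to compound 2 (0.06 log units; within the scatter), stayed within the scatter, which suggests that this part of the molecule tolerates modest variation. A step of about a 1.3-fold higher number from compound 3 to compound 4 (0.12 log units; within the scatter) is therefore expected, with no clear direction beyond the scatter. Compound 4 is estimated to give 0.3 nM, with a likely range from 0.1 nM to 1 nM.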

Compound 4, inhibition constant: 5.5 nM
The estimate for compound 4 lay 18-fold (1.26 log units) below the measured number; the measured number lies above the stated range.
By their numbers in this assay, from the lowest: compound 3; then compounds 4, 2 and 1 (each within the scatter of the next).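

Placing isopropyl instead of methyl on the carbonyl carbon gives a large loss of binding, a 24-fold higher number from compound 3 to compound 4 (1.38 log units; beyond the scatter), so the group at this position can strongly change the number. The earlier step on a chain at the carbonyl carbon, a 1.2-fold lower number from compound 1 to compound 2 (0.06 log units; within the scatter), stayed within the scatter, but it was a different change on a different core, so it did not predict how this position would respond here. This change involves only carbon, with one heavy atom leaving and three entering, and no data shown here explain the loss.

Going by these compounds, it remains open whether a cyclopropyl or a longer straight chain on the carbonyl carbon would stay close to compound 3 at 0.23 nM or fall nearer compound 4. How an amine or a carboxylic acid at this place would behave is also unknown.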